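Replacing the anilino group of compound 3

The source may report more compounds than this note shows. Statements on the series, on what has been measured and on what is new or still open speak of the compounds shown alone.

Measured in a functional assay on MCF7 cells (Homo sapiens) for antiproliferative activity; a higher number here means a weaker inhibitor, a lower number a stronger inhibitor:
compound 1 `CC(C)=CCc1cc(C(=O)Nc2cc3ccc(OCC4CCN(C)C4)c(C)c3oc2=O)ccc1O`: 1550 nM
compound 2 `CC(C)=CCc1cc(C(=O)Nc2cc3ccc(OCCCN(C)C(C)(C)C)c(C)c3oc2=O)ccc1O`: 1140 nM
compound 3 `CC(C)=CCc1cc(C(=O)Nc2cc3ccc(OCCCNc4ccccc4)c(C)c3oc2=O)ccc1O`: > 50000 nM (a limit, not a number)

Compound 3 stands at the limit of the assay, with no number of its own. Compound 4 `CC(C)=CCc1cc(C(=O)Nc2cc3ccc(OCCCN(C)Cc4ccccc4)c(C)c3oc2=O)ccc1O` differs from it in one place: benzyl(methyl)amino in place of anilino on a saturated chain carbon, three bonds along the chain from an oxygen on an aromatic ring. There, benzyl(methyl)amino takes the place of anilino on a saturated chain carbon, three bonds along the chain from an oxygen on an aromatic ring.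

Two large steps bear on this: an at least 43-fold higher number from compound 2 to compound 3 (1.64 log units; beyond the scatter) and an at least 32-fold higher number from compound 1 to compound 3 (1.50 log units; beyond the scatter). The step of a 1.4-fold lower number from compound 1 to compound 2 (0.13 log units; within the scatter) stays within the scatter. Compound 4 carries benzyl(methyl)amino where compound 2 carries methyl(tert-butyl)amino, so the change resembles the step from compound 2 run in reverse.

A large step to a lower number is therefore expected in this assay (an at least 27-fold lower number from compound 3 to compound 4 (1.44 log units; beyond the scatter)) . For compound 4 the estimated value is 1800 nM, with an expected range from 500 nM to 8000 nM.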

Compound 4, half-maximal inhibitory concentration: 11500 nM
Beside the measured number, compound 4's estimate is 6.4-fold (0.81 log units) below it, and the stated range ends below it.
By their numbers in this assay, from the lowest: compounds 2 and 1 (each within the scatter of the next); then compound 4. At a limit, above all of these: compound 3.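

In this assay the change gives an at least 4.3-fold lower number from compound 3 to compound 4 (0.63 log units; beyond the scatter) and this step is only a bound, as the value of compound 3 is a limit: the limit of > 50000 nM in this assay, at which 1 of the 4 values shown sits. A benzyl group on the amine nitrogen still falls short of tert-butyl, giving a 10-fold higher number from compound 2 to compound 4 (1.00 log units; beyond the scatter) and the comparison with the 1-methylpyrrolidin-3-yl side chain gives a 7.4-fold higher number from compound 1 to compound 4 (0.87 log units; beyond the scatter). At this place, then, the group on the nitrogen matters even when the methyl stays. Open, on these data alone, is whether the aromatic ring itself accounts for this, which a cyclohexylmethyl group or a morpholine at the chain end could test.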